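Swapping the meta substituent: from nitrile to bromine

The compounds below may be only part of what the source reports. "The series", "measured", "known", "first", "only" and "open" are said of these compounds alone.

Measured compounds:
- compound 1, `COC(=O)C1=C(C)N=C(C)/C(=C(\O)OC)C1c1ccc(Cl)cc1`: 8130 nM
- compound 2, `COC(=O)C1=C(C)N=C(C)/C(=C(\O)OC)C1c1cccc(C)c1`: 110 nM
- compound 3, `COC(=O)C1=C(C)N=C(C)/C(=C(\O)OC)C1c1cccc(C#N)c1`: 34.7 nM

In a functional assay (muscle tissue) with Cavia porcellus as the target (a lower number here means that less compound is needed, a higher number that more compound is needed for the effect), compound 3 gives the lowest number of the three. Its nearest neighbour is compound 2, and the step of a 3.2-fold lower number from compound 2 to compound 3 (0.50 log units; beyond the scatter) lies beyond the scatter, so compound 3 is the most potent compound measured here. Compound 1 stands far away: the step of a 230-fold lower number from compound 1 to compound 3 (2.37 log units; beyond the scatter) is large.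

Compound 4, `COC(=O)C1=C(C)N=C(C)/C(=C(\O)OC)C1c1cccc(Br)c1`, has not yet been measured. Its structure differs from compound 3 in one place: bromo in place of cyano on an aromatic carbon

Among the measured compounds shown here, two steps bear on this change. The step of a 3.2-fold lower number from compound 2 to compound 3 (0.50 log units; beyond the scatter) shows that exchanging one group at this ring position for another moves the number only modestly. The steps of a 74-fold lower number from compound 1 to compound 2 (1.87 log units; beyond the scatter) and a 230-fold lower number from compound 1 to compound 3 (2.37 log units; beyond the scatter) show that the largest shifts came when the substituted position on the phenyl ring changed, not when one group at the same position was traded for another. Bromo keeps the position of cyano, so only a small step is expected in this assay, probably a slightly higher number than compound 3, and possibly none beyond the scatter.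

The estimate for compound 4 is therefore 55 nM, within 15 nM to 200 nM, a step of a 1.6-fold higher number from compound 3 to compound 4 (0.20 log units; within the scatter).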

Compound 4, half-maximal effective concentration: 1.29 nM
Estimate against measurement, compound 4: 43-fold (1.63 log units) above, outside the stated range (below it).
By their numbers in this assay, from the lowest: compound 4; then compound 3; then compound 2; then compound 1.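

In this assay, bromo in place of cyano gives a 27-fold lower number from compound 3 to compound 4 (1.43 log units; beyond the scatter) and bromo in place of methyl gives an 85-fold lower number from compound 2 to compound 4 (1.93 log units; beyond the scatter), so trading one group for another at this same place on the ring can move the number much further than the earlier 3.2-fold lower number from compound 2 to compound 3 (0.50 log units; beyond the scatter) had suggested. With a 6300-fold lower number from compound 1 to compound 4 (3.80 log units; beyond the scatter) as the widest step in the set, compound 4 is the most potent of the four compounds, and its steps to all the others lie beyond the scatter. The data shown include no measurement that would explain why bromo stands so far from cyano and methyl.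

Chlorine or iodine at this same place, or an amine or a carboxylic acid there, would show whether the low number is particular to bromo or extends to other groups. The step from compound 1 to compound 4 also changes both the halogen and its place on the ring, so the compounds shown leave the contribution of each of those two changes unresolved.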